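The source may report more compounds than this note shows. Statements on the series, on what has been measured and on what is new or still open speak of the compounds shown alone.

The shared core carries a short alkyl chain on an aromatic nitrogen, and three such compounds have been measured in an ADME assay on C8166 cells (Homo sapiens) for cytotoxicity, read by MTT assay; on this read-out lower numbers stand for higher toxicity in this test and higher numbers for lower toxicity in this test. Compound 1 `CCCCn1cc(C(=O)O)c(=O)c2c(O)c(Cc3cccc(Cl)c3F)ccc21` gives 20000 nM, compound 2 `CCCCCn1cc(C(=O)O)c(=O)c2c(O)c(Cc3cccc(Cl)c3F)ccc21` gives 39900 nM, and compound 3 `CC(C)Cn1cc(C(=O)O)c(=O)c2c(O)c(Cc3cccc(Cl)c3F)ccc21` gives 19500 nM. Compound 3 thus sits alongside compound 1 because a 1.0-fold lower number from compound 1 to compound 3 (0.01 log units; within the scatter), and somewhat apart from compound 2 because a 2.0-fold lower number from compound 2 to compound 3 (0.31 log units; beyond the scatter). Compound 4 `CC(C)(C)n1cc(C(=O)O)c(=O)c2c(O)c(Cc3cccc(Cl)c3F)ccc21` carries tert-butyl in place of isobutyl on an aromatic nitrogen. All three measured steps swap one chain for another at this same nitrogen: a 2.0-fold higher number from compound 1 to compound 2 (0.30 log units; within the scatter), a 1.0-fold lower number from compound 1 to compound 3 (0.01 log units; within the scatter) and a 2.0-fold lower number from compound 2 to compound 3 (0.31 log units; beyond the scatter). These swaps moved the number only slightly, so no step beyond the scatter is expected for a 1.0-fold higher number from compound 3 to compound 4 (0.01 log units; within the scatter). Compound 4 is therefore estimated at 20000 nM, within 10000 nM to 40000 nM.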

Compound 4, half-maximal cytotoxic concentration: 400000 nM
Beside the measured number, compound 4's estimate is 20-fold (1.30 log units) below it, and the stated range ends below it.
By their numbers in this assay, from the lowest: compounds 3, 1 and 2 (each within the scatter of the next, the first and the last beyond it); then compound 4.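

At this nitrogen, the arrangement of the carbons counts, not just their number: isobutyl and tert-butyl hold the same atoms, yet there is a 21-fold higher number from compound 3 to compound 4 (1.31 log units; beyond the scatter) in this assay, which here means lower toxicity in this test. The straight chains compare in the same direction, with a 20-fold higher number from compound 1 to compound 4 (1.30 log units; beyond the scatter) and a 10-fold higher number from compound 2 to compound 4 (1.00 log units; beyond the scatter), so tert-butyl stands clear of all three earlier chains. Nothing shown here offers a reason for this jump. Still open, from the compounds shown here alone, is whether other branched groups on this nitrogen, such as a cyclopropyl ring or a longer chain branched at its first carbon, behave like tert-butyl.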